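This account rests on a few compounds, and the source may have more. Where it says the series, first, only, none or still open, it means among the compounds named here.

Compound 3 `Cn1nc(Cc2nnc(SCCCCCCCC(=O)Nc3ccc(Cl)cc3Cl)n2CCC=O)c2ccccc2c1=O` stands second highest of the three numbers in an assay on 32D cells for inhibition of interleukin-15 (Mus musculus), read by resazurin assay, with stated times of 30 min and 2.5 days, in the presence of a further agent that is not named here; a higher number here means a weaker inhibitor, a lower number a stronger inhibitor. In this assay compound 3 gives 2500 nM, compound 1 `Cn1c(Cc2nn(C)c(=O)c3ccccc23)nnc1SCCCCCCCC(=O)Nc1ccc(Cl)cc1Cl` gives 2200 nM and compound 2 `CCOC(CCn1c(Cc2nn(C)c(=O)c3ccccc23)nnc1SCCCCCCCC(=O)Nc1ccc(Cl)cc1Cl)OCC` gives 12100 nM. All three differ only in the group on the aromatic nitrogen of the shared core. Compound 4 `Cn1nc(Cc2nnc(SCCCCCCCC(=O)Nc3ccc(Cl)cc3Cl)[nH]2)c2ccccc2c1=O` removes that group entirely: hydrogen in place of 2-formylethyl on an aromatic nitrogen. Among the measured compounds shown here, the steps that bear on this change are a 1.1-fold higher number from compound 1 to compound 3 (0.06 log units; within the scatter) and a 4.8-fold lower number from compound 2 to compound 3 (0.68 log units; beyond the scatter); the first shows that exchanging methyl for a short oxygen-bearing chain leaves the number unchanged, while a 5.5-fold higher number from compound 1 to compound 2 (0.74 log units; beyond the scatter) shows that the larger acetal chain weakens. For the measured compounds named here, no measured pair strips the nitrogen to hydrogen, so the effect of removing the chain is inferred only from these. Since the smaller substituents sit together within the scatter, compound 4 is expected to change little, no change at the digits printed from compound 3 to compound 4 (within the scatter). Compound 4 is therefore estimated at 2500 nM, with a range from 1000 nM to 6500 nM.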

Compound 4, half-maximal inhibitory concentration: 1100 nM
For compound 4 the middle estimate is 2.3-fold (0.36 log units) above the measured one, within the range that was stated.
By their numbers in this assay, from the lowest: compounds 4, 1 and 3 (each within the scatter of the next, the first and the last beyond it); then compound 2.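

In this assay, among the compounds shown here, compound 4 gives the first reading with no group on this aromatic nitrogen, and hydrogen in place of methyl gives a 2.0-fold lower number from compound 1 to compound 4 (0.30 log units; within the scatter) so this small group and hydrogen cannot be told apart. Against the two longer chains hydrogen does separate: hydrogen in place of 2-formylethyl gives a 2.3-fold lower number from compound 3 to compound 4 (0.36 log units; beyond the scatter) and hydrogen in place of 3,3-diethoxypropyl gives an 11-fold lower number from compound 2 to compound 4 (1.04 log units; beyond the scatter) with the larger step belonging to the larger chain. Nothing measured here gives a reason for these steps.

From the compounds shown here alone, whether a plain propyl chain, free of oxygen, would stand with hydrogen or with 2-formylethyl remains open. So does the effect of an amine or a carboxylic acid at the end of that chain on this aromatic nitrogen.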